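The source may report more compounds than this note shows. Statements on the series, on what has been measured and on what is new or still open speak of the compounds shown alone.

Measured compounds in the series:
- compound 1 `COC(=O)[C@@H](C)NC(=O)Cn1cc(C2=C(c3c[nH]c4ccccc34)C(=O)N(C)C2=O)c2ccccc21`: 21400 nM
- compound 2 `COC(=O)[C@@H](CO)NC(=O)Cn1cc(C2=C(c3c[nH]c4ccccc34)C(=O)N(C)C2=O)c2ccccc21`: 22900 nM

Among the measured compounds shown here, in a functional assay on HCT-8 cells (Homo sapiens) for cytotoxicity, read by MTT assay, with a stated time of 24 h (a higher number here means a weaker inhibitor, a lower number a stronger inhibitor), compound 2 gives 22900 nM, the higher of the two numbers measured so far; compound 1 sits nearest with 21400 nM, and the two lie within the scatter of each other.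

The next compound, compound 3 `COC(=O)CC[C@@H](NC(=O)Cn1cc(C2=C(c3c[nH]c4ccccc34)C(=O)N(C)C2=O)c2ccccc21)C(=O)OC`, carries (methoxycarbonyl)methyl in place of hydroxy on a saturated chain carbon, two bonds along the chain from an amide-type nitrogen and a carbonyl carbon relative to compound 2.

For the measured compounds named here, only one measured step bears on this position: a 1.1-fold higher number from compound 1 to compound 2 (0.03 log units; within the scatter). That step, at the same saturated chain carbon, left the number unchanged within the scatter, so the position has so far shown no sensitivity in this assay. Going by the values given here, the present change swaps one small group for a larger one at the same site, but there is no step in the data on which to base a shift in either direction. The expected step is therefore a 1.0-fold higher number from compound 2 to compound 3 (0.00 log units; within the scatter), none beyond the scatter.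

Compound 3 is estimated at 23000 nM in this assay, with a range from 11000 nM to 48000 nM.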

Compound 3, half-maximal inhibitory concentration: 29200 nM
The estimate for compound 3 lay 1.3-fold (0.10 log units) below the measured number; the measured number falls inside the stated range.
By their numbers in this assay, from the lowest: compounds 1, 2 and 3 (each within the scatter of the next).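

In this assay, (methoxycarbonyl)methyl in place of hydroxy on the saturated chain carbon gives a 1.3-fold higher number from compound 2 to compound 3 (0.11 log units; within the scatter) and the same group in place of hydrogen gives a 1.4-fold higher number from compound 1 to compound 3 (0.13 log units; within the scatter) so both steps stay inside the scatter. The position, so far read only for hydrogen against hydroxy, now also shows no measurable response to a group of 5 heavy atoms, which enters with 0 hydrogen-bond donors where hydroxy had 1, so this site takes a substantially larger ester-bearing side chain with the number unchanged in this cell read-out. Nothing at hand offers an explanation for this flat response.

Going by these compounds, whether a free carboxylic acid in place of the side-chain ester, or an amine on this chain, would move the number beyond the scatter remains open. On these data alone, a longer chain at this carbon remains equally open.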